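Replacing 3,5-dimethoxyphenyl with 4-fluorophenyl on compound 3

The source may hold more compounds than are shown below. What is called first, only, known or untested is meant among the compounds shown, and "the series" means these compounds.

In an ADME assay on L02 cells (Homo sapiens) for cytotoxicity, read by MTT assay, with a stated time of 24 h (on this read-out lower numbers stand for stronger inhibition and higher numbers for weaker inhibition), compound 3 (`COc1cc(/C=C2\CN(C)C/C(=C\c3cc(OC)c(OC)c(OC)c3)C2=O)cc(OC)c1`) gives 14600 nM. Its nearest neighbour is compound 1 (`COc1cc(/C=C2\CN(C)C/C(=C\c3ccccc3F)C2=O)cc(OC)c1OC`) at 12100 nM, and the furthest is compound 2 (`COc1cc(/C=C2\CN(C)C/C(=C\c3ccc(F)cc3)C2=O)cc(OC)c1`) at 21900 nM. Both gaps lie within the usual scatter of repeated measurements, so neither compound can be ranked against compound 3.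

The next compound, compound 4 (`COc1cc(/C=C2\CN(C)C/C(=C\c3ccc(F)cc3)C2=O)cc(OC)c1OC`), carries 4-fluorophenyl in place of 3,5-dimethoxyphenyl on a double-bonded chain carbon bound to a double-bonded ring carbon.

Among the compounds with values here, one measured step touches this same place: a 1.2-fold higher number from compound 1 to compound 3 (0.08 log units; within the scatter). In that step 3,5-dimethoxyphenyl stands in place of 2-fluorophenyl, so it is a close relative of the present swap read in reverse, though not the identical group. It stayed within the scatter. Compound 2, which also carries 4-fluorophenyl, gives 21900 nM, a number that also sits within the scatter of compound 3. This is thin evidence, but nothing in it points to a real shift in either direction.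

The expected change is therefore none beyond the scatter, an estimated 1.0-fold higher number from compound 3 to compound 4 (0.01 log units; within the scatter). For compound 4 the estimated value is 15000 nM, with an expected range from 8000 nM to 28000 nM.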

Compound 4, half-maximal inhibitory concentration: 10700 nM
Beside the measured number, compound 4's estimate is 1.4-fold (0.15 log units) above it, and the stated range covers the measured number.
By their numbers in this assay, from the lowest: compounds 4, 1, 3 and 2 (each within the scatter of the next, the first and the last beyond it).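

In this assay, the place on a double-bonded chain carbon bound to a double-bonded ring carbon now has three groups compared, and 4-fluorophenyl in place of 3,5-dimethoxyphenyl gives (a 1.4-fold lower number from compound 3 to compound 4 (0.13 log units; within the scatter)), while 4-fluorophenyl in place of 2-fluorophenyl gives (a 1.1-fold lower number from compound 1 to compound 4 (0.05 log units; within the scatter)), so these phenyl groups cannot be told apart here. Within the data shown here, the new information comes from the other side of the comparison: methoxy in place of hydrogen on an aromatic carbon gives (a 2.0-fold lower number from compound 2 to compound 4 (0.31 log units; beyond the scatter)), the first step to pass the scatter, though only modestly, with compound 4 reading as the stronger of that pair. No measurement shown here offers an explanation for that step.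

On these data alone, the methoxy step rests on this single pair, so it remains open whether it would repeat with a different group on the double-bonded chain carbon. As far as these compounds go, it also remains open whether this place would stay as undemanding with something other than a substituted phenyl ring, for example a phenyl ring carrying a carboxylic acid or an amine.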